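Changing the Acyl Ring on a Carbonyl Carbon

This account rests on a few compounds, and the source may have more. Where it says the series, first, only, none or still open, it means among the compounds named here.

In a functional assay on SU-DHL-6 cells (Homo sapiens) for antiproliferative activity, read by MTT assay (on this read-out higher numbers stand for weaker inhibition and lower numbers for stronger inhibition), compound 2 `COc1ncc(-c2ccc3ncnc(N[C@H]4CCCN(C(=O)c5cccnc5)C4)c3c2)cc1C#N` gives 120 nM and compound 1 `COc1ncc(-c2ccc3ncnc(N[C@H]4CCCN(C(=O)C(F)(F)F)C4)c3c2)cc1C#N` gives 210 nM and these two numbers lie within the scatter of each other, so neither stands clearly apart. Compound 3 `COc1ncc(-c2ccc3ncnc(N[C@H]4CCCN(C(=O)C5CCNCC5)C4)c3c2)cc1C#N` keeps the shared core but has piperidin-4-yl in place of pyridin-3-yl on a carbonyl carbon, the difference being piperidin-4-yl in place of pyridin-3-yl on a carbonyl carbon with nothing else altered. For the measured compounds named here, only one measured step bears on this place, a 1.8-fold lower number from compound 1 to compound 2 (0.24 log units; within the scatter) for a different swap on that same carbonyl carbon, and it stays within the scatter. Going by the values given here, no measured compound yet carries a non-aromatic ring there, so the data offer only weak guidance on this swap. From the compounds shown here alone, on that evidence no change beyond the scatter is expected in this assay and the direction remains open. The estimate means a 1.3-fold higher number from compound 2 to compound 3 (0.10 log units; within the scatter) as the expected step, which is not beyond the scatter. For compound 3 the estimated value is 150 nM with an expected range from 50 nM to 450 nM allowing for the thin evidence.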

Compound 3, half-maximal inhibitory concentration: 2440 nM
Beside the measured number, compound 3's estimate is 16-fold (1.21 log units) below it, and the stated range ends below it.
By their numbers in this assay, from the lowest: compounds 2 and 1 (each within the scatter of the next); then compound 3.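

In this assay, for the compounds shown here, the group on this carbonyl carbon now clearly matters: the swap to piperidin-4-yl gives a 20-fold higher number from compound 2 to compound 3 (1.31 log units; beyond the scatter), and replacing trifluoromethyl with the same ring gives a 12-fold higher number from compound 1 to compound 3 (1.07 log units; beyond the scatter), whereas the only earlier step at this place stayed within the scatter. Pyridin-3-yl and piperidin-4-yl have the same count of heavy atoms, so that count does not separate them, yet they differ in that one ring is aromatic and the other is non-aromatic and brings a hydrogen-bond donor. No supporting measurement is available to explain why the number rises with this swap.

The compounds shown leave open whether the step follows the non-aromatic ring, the hydrogen-bond donor or both, since these differences enter together in compound 3. A cyclohexyl ring, which has no ring nitrogen, or a piperidin-4-yl with a methyl group on its ring nitrogen, would help to tell these possibilities apart on this carbonyl carbon.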